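Branched saturated acid chain in place of the unsaturated one

A few compounds are considered here, and "the series" means these few. Any claim that something is new, unique, unknown or untested is made for them only; others in the source may bear on it.

Of the compounds shown here, three have been measured in a functional assay on CHO cells for agonist activity at Free fatty acid receptor 1 (Homo sapiens), read by a luciferase reporter; a higher number here means a larger maximal response, a lower number a smaller maximal response. Compound 1 `Cc1nc(-c2ccc(C(F)(F)F)cc2)sc1CNc1ccc(CCC(=O)O)cc1` gives 108%, compound 2 `Cc1nc(-c2ccc(C(F)(F)F)cc2)sc1CNc1ccc(CCCC(=O)O)cc1` gives 44%, and compound 3 `O=C(O)/C=C/c1ccc(NCc2cccc(Oc3ccccc3)c2)cc1` gives 76%. Compound 3 therefore stands second of the three, below compound 1 and above compound 2, and both of those gaps lie beyond the scatter. Within the data shown here, the one single-point step among the measured compounds is a number 64 percentage points lower from compound 1 to compound 2 (beyond the scatter), a large fall.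

Compound 4 `CC(CC(=O)O)c1ccc(NCc2cccc(Oc3ccccc3)c2)cc1` differs from compound 3 in one place: 1-(carboxymethyl)ethyl in place of 2-carboxyethenyl on an aromatic carbon. The acid-bearing chain stays the same in reach but loses its double bond and gains a branch. Among the measured compounds shown here, the large step from compound 1 to compound 2 is the only guide, and it concerns a carboxymethyl in place of carboxy, which is not what happens here, so it bears only loosely on this change. A saturated chain of the present kind sits on compound 1, which gives the highest number seen. The expected step of a number 1 percentage points lower from compound 3 to compound 4 (within the scatter) is therefore small, possibly within the scatter, with some downward risk. For compound 4 the estimate in this assay is 75%, with a range from 45% to 105%.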

Compound 4, largest response reached (reported as percent of maximum), in percent of the reference or control that the assay uses: 83%
The estimate for compound 4 lay 8 percentage points below the measured number; the range from low to high includes it.
By their numbers in this assay, from the lowest: compound 2; then compounds 3 and 4 (each within the scatter of the next); then compound 1.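

In this assay, placing 1-(carboxymethyl)ethyl instead of 2-carboxyethenyl on this aromatic carbon, para to a large group, gives a number 7 percentage points higher from compound 3 to compound 4 (within the scatter) and so leaves the two compounds indistinguishable. Among these compounds, this is the first evidence that, on this core, the maximal response holds when the entering group has one double bond outside aromatic rings where the leaving group has two, and six heavy atoms where it has five. It also stands apart from the other listed change to an acid-bearing group, a number 64 percentage points lower from compound 1 to compound 2 (beyond the scatter) on a different core, so such changes are not uniformly costly or uniformly harmless, though no measurement here explains why compound 3 and compound 4 cannot be separated.

The loss of the double bond and the gain of the branch came together in this one step, leaving their separate contributions open; a plain unbranched 2-carboxyethyl group on the same core would pull them apart. Also open, from the compounds shown here alone, is how far the response depends on the carboxylic acid itself, a question that a primary amide or a tetrazole at the end of this chain would address.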